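This account rests on a few compounds, and the source may have more. Where it says the series, first, only, none or still open, it means among the compounds named here.

The measured compounds so far:
compound 1, `O=[N+]([O-])c1cc(C(F)(F)F)cc([N+](=O)[O-])c1Oc1ccc(Br)cc1/C=N\OCc1ccccc1`, giving 2240 nM in a functional assay on A549 cells (Homo sapiens) for antiproliferative activity, read by MTT assay, with a stated time of 48 h; on this read-out lower numbers stand for stronger inhibition and higher numbers for weaker inhibition;
compound 2, `O=[N+]([O-])c1cc(C(F)(F)F)cc([N+](=O)[O-])c1Oc1c(Br)cc(Br)cc1/C=N\OCc1ccccc1`, giving 2150 nM in this assay.

Compound 2 and compound 1 cannot be told apart on these numbers: the step of a 1.0-fold lower number from compound 1 to compound 2 (0.02 log units; within the scatter), so the added bromo on an aromatic carbon made no visible difference. Compound 3, `O=[N+]([O-])c1cc(C(F)(F)F)cc([N+](=O)[O-])c1Oc1c(Br)cc(Br)cc1/C=N/OCc1ccc(Cl)cc1Cl`, differs from compound 2 in one place: a group of 12 heavy atoms (8 carbon, 1 nitrogen, 1 oxygen, 2 chlorine; one six-membered aromatic ring of carbon only) in place of a group of 10 heavy atoms (8 carbon, 1 nitrogen, 1 oxygen; one six-membered aromatic ring of carbon only), on an aromatic carbon. For the measured compounds named here, the only step measured so far, a 1.0-fold lower number from compound 1 to compound 2 (0.02 log units; within the scatter), concerns a different part of the molecule and gives no guidance on how the group carrying two chlorines will behave. With nothing pointing either way, no shift beyond the usual scatter is expected in this assay. The estimate for compound 3 is therefore 1900 nM, with a range from 600 nM to 6000 nM. This estimate means an expected step of a 1.1-fold lower number from compound 2 to compound 3 (0.05 log units; within the scatter).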

Compound 3, half-maximal inhibitory concentration: 6190 nM
Beside the measured number, compound 3's estimate is 3.3-fold (0.51 log units) below it, outside the stated range (above it).
By their numbers in this assay, from the lowest: compounds 2 and 1 (each within the scatter of the next); then compound 3.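

In this assay, the change to this group gives the first shift in the series that lies beyond the usual scatter, a 2.9-fold higher number from compound 2 to compound 3 (0.46 log units; beyond the scatter). The position, on an aromatic carbon ortho to a large group and meta to two bromo groups, is therefore one where a change can alter the antiproliferative read-out, and this change weakens it modestly. No measurement shown here accounts for the shift.

The entering group carries two chlorines, and its double bond is also drawn with the opposite geometry, so this single step cannot separate those two differences. Going by these compounds, it also remains open how a single chlorine, a methoxy group or an amine on that ring would behave in this assay.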